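The source may hold more compounds than are shown below. What is called first, only, known or untested is meant among the compounds shown, and "the series" means these compounds.

Measured so far in an ADME assay on RAW264.7 cells (Mus musculus) for cytotoxicity, read by MTT assay; on this read-out higher numbers stand for weaker inhibition and lower numbers for stronger inhibition:
- Compound 1 `CCCCCCCCCCOc1cccc(O)c1C(=O)/C=C/c1ccc(O)cc1`: > 30000 nM
- Compound 2 `CCCCCCCCCCOc1cccc(O)c1C(=O)/C=C/c1cc(OC)c(O)c(OC)c1`: > 30000 nM
- Compound 3 `CCCCCCCCCCOc1cccc(O)c1C(=O)/C=C/c1cccc(O)c1`: > 30000 nM

Compound 3 stands at > 30000 nM, which is a limit of the assay and not a number. The entries for compound 1 and compound 2 are limits too.

Compound 4 `CCCCCCCCCCOc1cccc(O)c1C(=O)/C=C/c1ccccc1O` differs from compound 3 in one place: 2-hydroxyphenyl in place of 3-hydroxyphenyl on a double-bonded chain carbon bound to a double-bonded chain carbon. The nearest measured change is a step that the two limits leave unreadable from compound 1 to compound 3. The other two are a step that the two limits leave unreadable from compound 1 to compound 2 and a step that the two limits leave unreadable from compound 2 to compound 3. None of these gives a size or a direction to carry over, so no step beyond the usual scatter is expected in this assay. The expected change is a step that the limit leaves unreadable from compound 3 to compound 4. The estimated value for compound 4 is 35000 nM, with an expected range of 15000 nM to 80000 nM.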

Compound 4, half-maximal inhibitory concentration: > 30000 nM
Compound 4: a limit, no number; the forecaster's own chance of this, stated with the estimate: 75%; the middle value lies beyond the limit too.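

Compound 4 gives a limit and not a number in this assay and no step from compound 1, compound 2 or compound 3 to compound 4 can be read: the limit of > 30000 nM in this assay, at which 4 of the 4 values shown sit.

The compounds shown leave open whether any of these groups gives a lower number in this assay and by how much.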